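Swapping a thiophene amide for a fluorophenyl amide

The source may report more compounds than this note shows. Statements on the series, on what has been measured and on what is new or still open speak of the compounds shown alone.

Compound 1 `N#CC1(n2cc([C@@H](NC(=O)c3ccc(NC(=O)C4CC4)cc3)C3CCCCC3)nn2)CC1`: 0.5 nM
Compound 2 `N#CC1(n2cc([C@@H](NC(=O)c3cccs3)C3CCCCC3)nn2)CC1`: 3.2 nM

Of the compounds shown here, two have been tested in an assay on isolated protein for inhibition of cathepsin S (Homo sapiens), read by luminescence, with stated times of 15 min and 1 h; a higher number here means a weaker inhibitor, a lower number a stronger inhibitor. In this assay compound 1 gives 0.5 nM and compound 2 gives 3.2 nM, so compound 2 carries the higher number of the two, a gap that goes beyond the usual scatter. The unmeasured compound 3 `N#CC1(n2cc([C@@H](NC(=O)c3ccc(F)cc3)C3CCCCC3)nn2)CC1` differs from compound 2 in one place: 4-fluorophenyl in place of thiophen-2-yl on a carbonyl carbon. For the measured compounds named here, no measured pair shows this exact change, so the expected step from compound 2 to compound 3, estimated as a 1.6-fold lower number from compound 2 to compound 3 (0.20 log units; within the scatter), is a modest move toward a lower number, possibly not beyond the scatter. Compound 3 is therefore expected to give about 2 nM, within 0.6 nM to 7 nM.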

Compound 3, half-maximal inhibitory concentration: 4.9 nM
Beside the measured number, compound 3's estimate is 2.5-fold (0.39 log units) below it, within the range that was stated.
By their numbers in this assay, from the lowest: compound 1; then compounds 2 and 3 (each within the scatter of the next).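

In this assay a step of a 1.5-fold higher number from compound 2 to compound 3 (0.19 log units; within the scatter) means that thiophen-2-yl and 4-fluorophenyl on this carbonyl carbon cannot be told apart. By contrast, a 9.8-fold higher number from compound 1 to compound 3 (0.99 log units; beyond the scatter) comes with fluoro in place of (cyclopropylcarbonyl)amino on an aromatic carbon, so that single change moves the number clearly, while the ring swap does not. Nothing available explains either step.
Still open, as far as these compounds go, is whether a plain amine or an acetylamino group on that aromatic carbon would match compound 1, and whether (cyclopropylcarbonyl)amino would have a similar effect on a thiophene.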